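Thiomorpholine for morpholine on compound 3

A few compounds are considered here, and "the series" means these few. Any claim that something is new, unique, unknown or untested is made for them only; others in the source may bear on it.

Measured so far:
compound 1 `N/C(=N\NC(=S)N1CCOCC1)c1ccccn1`: 4700 nM in a functional assay on MCF7 cells (Homo sapiens) for cytotoxicity, read by MTT assay, with a stated time of 72 h; a higher number here means a weaker inhibitor, a lower number a stronger inhibitor
compound 2 `N/C(=N\NC(=S)N1CCN(c2ccccn2)CC1)c1ccc(F)cn1`: 22000 nM
compound 3 `Cc1ccnc(/C(N)=N/NC(=S)N2CCOCC2)c1`: > 100000 nM

Compound 3 gives no number in this assay, only (the limit of > 100000 nM in this assay, at which 1 of the 3 values shown sits). Its value is therefore a limit and not a measurement. Among the measured compounds shown here, the one measured step that leads to it, an at least 21-fold higher number from compound 1 to compound 3 (1.32 log units; beyond the scatter), comes from methyl in place of hydrogen on an aromatic carbon and is large. For the measured compounds named here, compound 2 stands at 22000 nM, with no single-change step to either other compound.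

Compound 4 `Cc1ccnc(/C(N)=N/NC(=S)N2CCSCC2)c1` keeps the core of compound 3 and differs by thiomorpholin-4-yl in place of morpholin-4-yl on a thiocarbonyl carbon. Going by the values given here, no measured step touches this exchange; the only step in hand concerns a different position. With compound 3 at a limit, the expected step of a number no higher from compound 3 to compound 4 (the limit leaves the size open) is none beyond the scatter, and compound 4 is expected to sit at or beyond that limit as well. The estimate for compound 4 is 100000 nM, with a range from 30000 nM to 300000 nM.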

Compound 4, half-maximal inhibitory concentration: 6900 nM
Estimate against measurement, compound 4: 14-fold (1.16 log units) above; the whole stated range lies above it.
By their numbers in this assay, from the lowest: compounds 1 and 4 (each within the scatter of the next); then compound 2. At a limit, above all of these: compound 3.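

In this assay, thiomorpholin-4-yl in place of morpholin-4-yl on the thiocarbonyl carbon gives an at least 14-fold lower number from compound 3 to compound 4 (1.16 log units; beyond the scatter), so this position strongly affects the read-out in the methyl-bearing series. With the methyl kept, compound 4 gives 6900 nM, which shows that the methyl-bearing core can carry a measured value when the ring is thiomorpholin-4-yl. The full size of the step remains open because compound 3 stands at a limit: the limit of > 100000 nM in this assay, at which 1 of the 4 values shown sits.

Going by these compounds, whether the same ring exchange has a comparable effect on the core of compound 1, without the methyl, remains open, so any dependence of the methyl step on the ring cannot yet be read. Also open, on these data alone, is what a piperidine ring or the thiomorpholine sulfone would give on the same thiocarbonyl carbon.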